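Replacing the phenylethylamine of compound 3 with a prenylamine

The source may report more compounds than this note shows. Statements on the series, on what has been measured and on what is new or still open speak of the compounds shown alone.

Measured in an assay on CHO cells for displacement of a labelled ligand from 5-hydroxytryptamine receptor 1D (Homo sapiens); a lower number here means a stronger inhibitor, a higher number a weaker inhibitor:
compound 1 `c1ccc(CNCC2CCN(CCCc3c[nH]c4ccc(-n5cnnc5)cc34)CC2)cc1` gives 1.6 nM
compound 2 `CC(C)=CCCN(C)C1CCN(CCCc2c[nH]c3ccc(-n4cnnc4)cc23)CC1` gives 2.6 nM
compound 3 `C[C@@H](NC1CCN(CCCc2c[nH]c3ccc(-n4cnnc4)cc23)CC1)c1ccccc1` gives 0.4 nM

Compound 3 holds the lowest number of the three: a 4.0-fold lower number from compound 1 to compound 3 (0.60 log units; beyond the scatter) and a 6.5-fold lower number from compound 2 to compound 3 (0.81 log units; beyond the scatter), both beyond the scatter. Compound 4 `CC(C)=CCN(C)C1CCN(CCCc2c[nH]c3ccc(-n4cnnc4)cc23)CC1` differs from compound 3 in one place: methyl(3-methylbut-2-en-1-yl)amino in place of (1-phenylethyl)amino on a saturated ring carbon. The step bearing most closely on this change is the reverse of a 6.5-fold lower number from compound 2 to compound 3 (0.81 log units; beyond the scatter), compound 2 carrying the closely related methyl(4-methylpent-3-en-1-yl)amino group; a 4.0-fold lower number from compound 1 to compound 3 (0.60 log units; beyond the scatter) points the same way. A modest rise in the number is therefore expected for compound 4, about a 6.3-fold higher number from compound 3 to compound 4 (0.80 log units; beyond the scatter), landing near the value of compound 2. Compound 4 is estimated at 2.5 nM, with a range from 0.8 nM to 8 nM.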

Compound 4, half-maximal inhibitory concentration: 0.5 nM
Compound 4: the middle estimate sits 5.0-fold (0.70 log units) above what was measured, outside the stated range (below it).
By their numbers in this assay, from the lowest: compounds 3 and 4 (each within the scatter of the next); then compounds 1 and 2 (each within the scatter of the next).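

In this assay, the open-chain methyl(3-methylbut-2-en-1-yl)amino group, with no ring and no hydrogen-bond donor, serves at this saturated ring carbon as well as (1-phenylethyl)amino (a 1.3-fold higher number from compound 3 to compound 4 (0.10 log units; within the scatter)). The length of the alkenyl chain counts, as the shorter group gives (a 5.2-fold lower number from compound 2 to compound 4 (0.72 log units; beyond the scatter)), and the same group also improves on (benzylamino)methyl (a 3.2-fold lower number from compound 1 to compound 4 (0.51 log units; beyond the scatter)). Nothing measured here offers a reason for these steps. The compounds shown leave open whether the double bond matters, which a saturated 3-methylbutyl chain would test, and whether the methyl on the amine nitrogen does.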